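This account rests on a few compounds, and the source may have more. Where it says the series, first, only, none or still open, it means among the compounds named here.

In a functional assay on A549 cells (Homo sapiens) for antiproliferative activity, read by MTT assay, with a stated time of 48 h (on this read-out higher numbers stand for weaker inhibition and lower numbers for stronger inhibition), three members of the series have numbers. Compound 1 (`COc1cc(-c2cccc3nc(-c4cccc(Br)c4)oc23)cc(OC)c1OC`) gives 2100 nM and compound 2 (`COc1cc(-c2cccc3nc(-c4ccc(C)cc4)oc23)cc(OC)c1OC`) gives 680 nM on this read-out. Compound 3 (`COc1cc(-c2cccc3nc(-c4cccc(C)c4)oc23)cc(OC)c1OC`) gives 16700 nM as the highest number of the three, which makes it the weakest inhibitor so far.

Next is compound 4 (`COc1cc(-c2cccc3nc(-c4ccco4)oc23)cc(OC)c1OC`), with furan-2-yl in place of 3-methylphenyl on an aromatic carbon of the shared core. Going by the values given here, no measured step brings in furan-2-yl, so the evidence is indirect. The largest step at this place is a 25-fold higher number from compound 2 to compound 3 (1.39 log units; beyond the scatter) with 3-methylphenyl in place of 4-methylphenyl, and it is large. Modest steps are an 8.0-fold higher number from compound 1 to compound 3 (0.90 log units; beyond the scatter) with methyl in place of bromo, and a 3.1-fold lower number from compound 1 to compound 2 (0.49 log units; beyond the scatter) with 4-methylphenyl in place of 3-bromophenyl.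

The numbers at this place therefore swing widely, and three compounds are a thin base. Compound 3 at 16700 nM sits at the high end, so a modest step to a lower number is expected in this assay rather than a further rise, though little or no change remains possible. The expected change is a 5.6-fold lower number from compound 3 to compound 4 (0.75 log units; beyond the scatter) on this estimate. For compound 4 the estimated value is 3000 nM with an expected range from 500 nM to 16000 nM on this read-out.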

Compound 4, half-maximal inhibitory concentration: 10300 nM
The estimate for compound 4 lay 3.4-fold (0.54 log units) below the measured number; the measured number falls inside the stated range.
By their numbers in this assay, from the lowest: compound 2; then compound 1; then compounds 4 and 3 (each within the scatter of the next).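

In this assay, furan-2-yl in place of 3-methylphenyl gives a 1.6-fold lower number from compound 3 to compound 4 (0.21 log units; within the scatter), so at this position the five-membered aromatic ring with one hetero atom cannot be told apart from 3-methylphenyl. Against the other two groups the same ring gives a 15-fold higher number from compound 2 to compound 4 (1.18 log units; beyond the scatter) and a 4.9-fold higher number from compound 1 to compound 4 (0.69 log units; beyond the scatter), so bringing in a ring oxygen and a hydrogen-bond acceptor does not reach the lower numbers held by 4-methylphenyl and 3-bromophenyl. No measurement in hand accounts for these differences between groups.

Open, going by these compounds, is whether 4-bromophenyl would stand with 4-methylphenyl or with 3-bromophenyl, and whether thiophen-2-yl, with sulfur in place of the furan oxygen, would stay with furan-2-yl. Also open, on these data alone, is what an amine or a carboxylic acid on the phenyl ring would do to the number at this position, and four compounds in one cell line give no general rule for it.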